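The source may report more compounds than this note shows. Statements on the series, on what has been measured and on what is new or still open speak of the compounds shown alone.

In a functional assay on KB cells (Homo sapiens) for cytotoxicity, read by MTT assay, with a stated time of 72 h (on this read-out lower numbers stand for stronger inhibition and higher numbers for weaker inhibition), compound 1 `COc1cc2ncnc(NNC(=S)NC(=O)c3ccc(Cl)cc3)c2cc1OC` gives 4590 nM, while compound 2 `COc1cc2ncnc(NNC(=S)NC(=O)c3ccc(C)cc3)c2cc1OC` gives 24200 nM. The change between them, (methyl in place of chloro on an aromatic carbon), produced a 5.3-fold higher number from compound 1 to compound 2 (0.72 log units; beyond the scatter). Compound 3 `O=C(NC(=S)NNc1ncnc2ccccc12)c1ccccc1Cl` is built on a different core; the difference between the two cores is not broken down here. In this assay compound 3 gives 7710 nM. Compound 4 `Cc1ccccc1C(=O)NC(=S)NNc1ncnc2ccccc12` has not yet been measured; it differs from compound 3 by methyl in place of chloro on an aromatic carbon, the same kind of change as before, though here the group sits ortho to a large group rather than para to a large group. Because the earlier step of a 5.3-fold higher number from compound 1 to compound 2 (0.72 log units; beyond the scatter) was modest yet beyond the scatter, a weakening step of similar direction is expected from compound 3 to compound 4, roughly a 3.9-fold higher number from compound 3 to compound 4 (0.59 log units; beyond the scatter). Compound 4 is therefore estimated at 30000 nM, likely between 10000 nM and 90000 nM.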

Compound 4, half-maximal inhibitory concentration: 2770 nM
Estimate against measurement, compound 4: 11-fold (1.03 log units) above, outside the stated range (below it).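

In this assay, methyl in place of chloro gave a 2.8-fold lower number from compound 3 to compound 4 (0.44 log units; beyond the scatter), so the step runs opposite to the one seen on the other core: the same change on two cores in this assay, a 5.3-fold higher number (0.72 log units; beyond the scatter) from compound 1 to compound 2 and a 2.8-fold lower number (0.44 log units; beyond the scatter) from compound 3 to compound 4, 15-fold (1.17 log units) apart, beyond the scatter of two such steps In these two pairs, then, neither the size nor the direction of this change carried over from one core to the other. This does not show why, since the pairs differ both in the core and in the place of the group, here ortho to a large group, and the data cannot separate the two.

On these data alone, it remains open how the change behaves with the group ortho to a large group on the core of compound 1. As far as these compounds go, it also remains open how fluoro or an amine would compare with chloro and methyl at this place.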